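Chain extension on compound 3: propyl to hexyl

This account rests on a few compounds, and the source may have more. Where it says the series, first, only, none or still open, it means among the compounds named here.

Compound 1 `CCc1cccc(NC(=O)N[C@H](C)c2ccccc2)c1` gives 71% in an ADME assay on the whole organism with Oryza sativa as the target, tested at 1 uM; a lower number here means a stronger effect, a higher number a weaker effect of the compound at the concentration tested.
Compound 2 `CCCc1ccc(NC(=O)N[C@H](C)c2ccccc2)cc1` gives 31% in this assay.
Compound 3 `CCCc1ccc(NC(=O)N[C@@H](C)c2ccccc2)cc1` gives 76% in this assay.

Compound 3 stands at the top of the three numbers in this assay. Its nearest neighbour is compound 1, whose number lies within the scatter of that of compound 3, so no order between the two can be read. Within the data shown here, its furthest neighbour is compound 2: the step of a number 45 percentage points higher from compound 2 to compound 3 (beyond the scatter) is the only single-point step measured, and it rests solely on (the fact that compounds 2 and 3 differ only in the configuration as drawn).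

The step to compound 4 `CCCCCCc1ccc(NC(=O)N[C@@H](C)c2ccccc2)cc1` is of a different kind: propyl in place of hydrogen on a saturated chain carbon, three bonds along the chain from an aromatic carbon. Among the measured compounds shown here, no measured step touches a change of this sort. Compounds 1 and 3 carry chains of different length on the core, but they also differ in other respects, and their two values lie within the scatter of each other. There is thus no measured evidence for a step beyond the scatter in this assay when the chain is lengthened, and none for a direction.

For compound 4 the expected number is therefore close to that of compound 3, at 70%, with a range from 45% to 90%. The expected step of a number 6 percentage points lower from compound 3 to compound 4 (within the scatter) is estimated to stay within the scatter.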

Compound 4, a percentage reported as activity, at one concentration (the size of the read-out at that concentration, not a potency): 100%
Estimate against measurement, compound 4: 30 percentage points below; measured number outside the range, above it.
By their numbers in this assay, from the lowest: compound 2; then compounds 1 and 3 (each within the scatter of the next); then compound 4.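

In this assay the propyl to hexyl change, with the configuration as drawn left as it is, gives a number 24 percentage points higher from compound 3 to compound 4 (beyond the scatter) and so shows that this saturated chain carbon is a place where a change in the chain alone moves the number beyond the scatter. Among these compounds, since a higher number means a weaker effect at the concentration tested, this change runs in the same direction as the only earlier step of this kind, a number 45 percentage points higher from compound 2 to compound 3 (beyond the scatter), which is a change of configuration and not of the chain. Nothing at hand accounts for the chain step, since the one available fact concerns configuration only.

From the compounds shown here alone, a single step gives no trend with chain length: whether butyl and pentyl fall on a steady path from propyl to hexyl, or whether a longer chain such as octyl goes further, stays open. Also open, going by these compounds, are the same lengthening in the configuration of compound 2, where the number starts from 31%, and whether an amine or a carboxylic acid on the chain would behave as the plain hexyl does.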